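Ether chain variation at the aromatic oxygen

The compounds below may be only part of what the source reports. "The series", "measured", "known", "first", "only" and "open" are said of these compounds alone.

Compound 2 `CC(C)COc1cc(C(C)(C)C)ccc1CNC(=O)C(C)c1ccc(NS(C)(=O)=O)c(F)c1` gives 2.1 nM in an assay on cells for antagonist activity at transient receptor potential cation channel subfamily V member 1 (Homo sapiens), read by FLIPR and calcium flux, with a stated time of 6 min (a lower number here means a stronger inhibitor, a higher number a weaker inhibitor), the lowest of the two numbers measured; its nearest neighbour, compound 1 `CC(C(=O)NCc1ccc(C(C)(C)C)cc1N1CCCC1)c1ccc(NS(C)(=O)=O)c(F)c1`, gives 8.1 nM. Going by the values given here, the one measured step, a 3.9-fold lower number from compound 1 to compound 2 (0.59 log units; beyond the scatter), concerns the same aromatic position but a different exchange. Compound 3 `CC(C(=O)NCc1ccc(C(C)(C)C)cc1OCc1ccc(F)cc1)c1ccc(NS(C)(=O)=O)c(F)c1` differs from compound 2 by 4-fluorophenyl in place of isopropyl on a saturated chain carbon bound to an oxygen on an aromatic ring, that is isobutoxy to (4-fluorobenzyl)oxy. Among the compounds with values here, no measured step tests lengthening of this ether chain, so the step of a 1.4-fold higher number from compound 2 to compound 3 (0.15 log units; within the scatter) is expected to stay within the scatter, with a wide range allowed. Compound 3 is estimated at 3 nM, between 0.8 nM and 12 nM.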

Compound 3, inhibition constant: 3.8 nM
Compound 3: middle estimate off by 1.3-fold (0.10 log units), on the low side; the measured number falls inside the stated range.
By their numbers in this assay, from the lowest: compounds 2 and 3 (each within the scatter of the next); then compound 1.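

In this assay, the 4-fluorobenzyl ether and the isobutyl ether are not separated (a 1.8-fold higher number from compound 2 to compound 3 (0.26 log units; within the scatter)), so this position accepts an aromatic ring on the ether chain as well as a branched alkyl chain. The (4-fluorobenzyl)oxy group also stands apart from pyrrolidin-1-yl (a 2.1-fold lower number from compound 1 to compound 3 (0.33 log units; beyond the scatter)), so among the compounds shown, both ethers give lower numbers than the pyrrolidine. No evidence on the origin of these numbers is available. Open, as far as these compounds go, is how methoxy, or an ether chain ending in an amine or a carboxylic acid, would read here.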